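The source may hold more compounds than are shown below. What is called first, only, known or untested is meant among the compounds shown, and "the series" means these compounds.

Of the compounds shown here, three from this series have been measured in a functional assay on ileum for inhibition of histamine H1 receptor (Cavia porcellus); on this read-out higher numbers stand for weaker inhibition and lower numbers for stronger inhibition. Compound 1, `CCCCN1CCCN(c2nc3ccccc3n2CCOCC)CC1`, gives 8.4 nM in this assay. Compound 2, `CCCOCCn1c(N2CCN(C)CC2)nc2ccccc21`, gives 20 nM, and compound 3, `CCOCCn1c(N2CCNCC2)nc2ccccc21`, gives 11 nM. Of the three numbers, that of compound 2 is the highest, but its gap to compound 3 falls within the usual scatter of repeated measurements, so no order between these two can be read from the data, whereas its gap to compound 1 lies beyond the scatter.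

Compound 4, `CC(C)CCn1c(N2CCN(C)CC2)nc2ccccc21`, has not yet been measured in this assay. It differs from compound 2 in one place: isopropyl in place of propoxy on a saturated chain carbon, two bonds along the chain from an aromatic nitrogen. For the measured compounds named here, no pair among the measured compounds shows what this kind of change does, since each of compounds 1, 2 and 3 carries an ether-containing chain on the aromatic nitrogen. Without such a comparison, the step from compound 2 is expected to be small, a 1.5-fold higher number from compound 2 to compound 4 (0.18 log units; within the scatter), with no clear direction beyond the scatter. Compound 4 is therefore estimated at 30 nM, within a range from 10 nM to 100 nM.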

Compound 4, half-maximal inhibitory concentration: 1400 nM
Compound 4: the middle estimate sits 47-fold (1.67 log units) below what was measured; the measured number lies above the stated range.
By their numbers in this assay, from the lowest: compounds 1, 3 and 2 (each within the scatter of the next, the first and the last beyond it); then compound 4.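

In this assay, isopropyl in place of propoxy on a saturated chain carbon, two bonds along the chain from an aromatic nitrogen, gives a 70-fold higher number from compound 2 to compound 4 (1.85 log units; beyond the scatter), a large step. For the compounds shown here, this place is therefore far from indifferent to the group it carries, something compounds 1, 2 and 3 could not show: each of them has an ether-containing chain on the aromatic nitrogen, and no pair among them isolates a change there. Nothing in the data shown accounts for the size of this step.

The change removes the oxygen and introduces a branch at once, so the data cannot say which of the two goes with the step. A straight butyl group at this place would separate them, and a hydroxyl group would test whether another oxygen-bearing group behaves like propoxy.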